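Trifluoromethyl in place of fluoro: half-life expectation for compound 4

The compounds below may be only part of what the source reports. "The series", "measured", "known", "first", "only" and "open" are said of these compounds alone.

In an ADME assay on microsomes from liver (Homo sapiens) for metabolic stability (on this read-out higher numbers stand for a longer-lived compound and lower numbers for a shorter-lived compound), compound 1 `CC(C)C(/C=C1\NC(=O)NC1=O)c1ccc(-c2ccc3cccc(F)c3c2)[nH]c1=O` gives > 3 h, which is a limit and not a number. Compound 2 `CC(C)C(CC1C(=O)NC(=O)N1C)c1ccc(-c2ccc3cccc(F)c3c2)[nH]c1=O` gives 0.153 h. Compound 3 `CCC(/C=C1\OC(=O)NC1=O)(CC)c1ccc(-c2ccc3cccc(F)c3c2)[nH]c1=O` gives 0.948 h, the higher of the two numbers, and the gap between these two is beyond the scatter.

Compound 4 `CCC(/C=C1\OC(=O)NC1=O)(CC)c1ccc(-c2ccc3cccc(C(F)(F)F)c3c2)[nH]c1=O` differs from compound 3 in one place, with trifluoromethyl in place of fluoro on an aromatic carbon. Among the measured compounds shown here, no measured step touches this fluoro. For the measured compounds named here, the only step available, an at least 19-fold lower number from compound 1 to compound 2 (1.29 log units; beyond the scatter), is large and beyond the scatter, but it exchanges a different group, on a saturated chain carbon, and so gives no size for the present change. Its size also rests on (the limit of > 3 h in this assay, at which 1 of the 3 values shown sits).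

The expectation therefore stays anchored on compound 3 at 0.948 h, and no change beyond the scatter is expected in this assay. The estimated step is a 1.2-fold lower number from compound 3 to compound 4 (0.07 log units; within the scatter), a small expected drop that stays within the scatter. The range is kept wide because an at least 19-fold lower number from compound 1 to compound 2 (1.29 log units; beyond the scatter) shows how far the half-life moved with one change elsewhere in the structure. For compound 4 the estimated half-life is 0.8 h, with an expected range from 0.3 h to 2 h.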

Compound 4, half-life: 0.353 h
For compound 4 the middle estimate is 2.3-fold (0.36 log units) above the measured one; low and high end bracket the measured number.
By their numbers in this assay, from the lowest: compound 2; then compound 4; then compound 3. At a limit, above all of these: compound 1.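

In this assay, the exchange of fluoro for trifluoromethyl on this aromatic carbon gives a 2.7-fold lower number from compound 3 to compound 4 (0.43 log units; beyond the scatter), so the half-life in this series responds to a change at this position of the fused two-ring system, and not only to the change on the saturated chain carbon in the earlier step. With trifluoromethyl in place of fluoro, this single pair shows that the position does not tolerate that exchange without a loss of half-life, though the loss is modest. Nothing available bears on why the number drops at this position.

With only fluoro and trifluoromethyl at this carbon, the compounds shown leave open whether the half-life falls steadily with the size of the group or whether trifluoromethyl is a special case; a chloro, a methoxy or a nitrile on the same carbon, or simple hydrogen there, would separate these readings. Also open, going by these compounds, is whether the same exchange costs a similar amount when the group on the saturated chain carbon differs from that of compound 3.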